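The compounds below may be only part of what the source reports. "The series", "measured", "known", "first", "only" and "open" are said of these compounds alone.

Measured in a functional assay on the whole organism (strain CF-1) with Mus musculus as the target; a higher number here means that more compound is needed for the effect, a lower number that less compound is needed:

Compound 1 `Cc1nnc(CN(C)C)n1-c1ccc(Cl)cc1C(=O)c1ccccc1`: 5 mg/kg
Compound 2 `CN(C)CCn1nc(CN(C)C)n(-c2ccc(Cl)cc2C(=O)c2ccccc2)c1=O`: 100 mg/kg
Compound 3 `Cc1nc(CN(C)C)n(-c2ccc(Cl)cc2C(=O)c2ccccc2Cl)c1CO`: 18 mg/kg

Among these three numbers compound 1 stands lowest, so the least compound is needed for the effect. The nearest of the other two is compound 3, whose value is higher by a gap beyond the usual scatter; the furthest is compound 2, whose value is higher by a much wider gap, also well beyond the scatter. Within the data shown here, none of the three pairs differ in a single place, so no single-point step among measured compounds is available as a guide.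

Compound 4 `Cc1nnc(CN2CCCC2)n1-c1ccc(Cl)cc1C(=O)c1ccccc1` has not yet been measured. It is derived from compound 1 by a change at one place: pyrrolidin-1-yl in place of dimethylamino on a saturated chain carbon bound to an aromatic carbon. The group that leaves and the group that enters each carry one hydrogen-bond acceptor and no donor and neither bears a net charge; the entering group adds a five-membered non-aromatic ring where an open chain stood.

With nothing in the measured set to calibrate such an exchange, the step of no change at the digits printed from compound 1 to compound 4 (within the scatter) is expected to be small, within the scatter, in either direction. Compound 4 is therefore expected to give about 5 mg/kg, within a range from 2 mg/kg to 15 mg/kg.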

Compound 4, dose for half-maximal effect: 4 mg/kg
Compound 4: the middle estimate sits 1.3-fold (0.10 log units) above what was measured; low and high end bracket the measured number.
By their numbers in this assay, from the lowest: compounds 4 and 1 (each within the scatter of the next); then compound 3; then compound 2.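

Among these compounds, the step of a 1.3-fold lower number from compound 1 to compound 4 (0.10 log units; within the scatter) in this assay is the first comparison in this set in which only one place changes, and it lies within the scatter. At this saturated chain carbon bound to an aromatic carbon, the exchange of (dimethylamino)methyl for (pyrrolidin-1-yl)methyl brings a five-membered non-aromatic ring where an open chain stood, yet it leaves no readable mark on the dose needed, so for this pair the open chain is not required. No measurement accompanies the step that could say how the amine group acts at this place or why the number holds.

On these data alone, it remains open whether the same place would accept a six-membered ring such as piperidin-1-yl or morpholin-4-yl, or a smaller amine such as methylamino or a free primary amine, and whether any of these would move the number beyond the scatter. This one exchange also says nothing about the other places on the core of compound 1, including the methyl group on its ring and the benzoyl group on the chlorinated ring.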